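A few compounds are considered here, and "the series" means these few. Any claim that something is new, unique, unknown or untested is made for them only; others in the source may bear on it.

Working notes on the series, read in a functional assay on A549 cells (Homo sapiens) for antiproliferative activity, read by CCK-8 assay, with a stated time of 72 h; a lower number here means a stronger inhibitor, a higher number a weaker inhibitor. Compound 2 `Nc1ccccc1NC(=O)c1ccc(COc2ccccc2)cc1` gives 6760 nM and compound 3 `CCc1ccc(OCc2ccc(C(=O)Nc3ccccc3N)cc2)cc1` gives 6420 nM, so compound 3 cannot be told apart from its nearest neighbour. Compound 1 `Nc1ccccc1NC(=O)c1ccc(COc2ccc(Cl)cc2)cc1` reports only a limit, > 32000 nM. Compound 4 `COc1ccc(OCc2ccc(C(=O)Nc3ccccc3N)cc2)cc1` has methoxy in place of ethyl on an aromatic carbon, para to a large group: methoxy in place of ethyl on an aromatic carbon. Two kinds of step bear on this position. The step of a 1.1-fold lower number from compound 2 to compound 3 (0.02 log units; within the scatter) stays within the scatter, whereas an at least 4.7-fold lower number from compound 1 to compound 2 (0.67 log units; beyond the scatter) and an at least 4.9-fold lower number from compound 1 to compound 3 (0.69 log units; beyond the scatter) go beyond it, and only the chloro compound stands apart. No step beyond the scatter is therefore expected, and the estimated step is a 1.0-fold higher number from compound 3 to compound 4 (0.01 log units; within the scatter). For compound 4 the estimated value is 6500 nM, with an expected range of 2500 nM to 20000 nM.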

Compound 4, half-maximal inhibitory concentration: 5530 nM
Beside the measured number, compound 4's estimate is 1.2-fold (0.07 log units) above it, within the range that was stated.
By their numbers in this assay, from the lowest: compounds 4, 3 and 2 (each within the scatter of the next). At a limit, above all of these: compound 1.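

In this assay, the step of a 1.2-fold lower number from compound 3 to compound 4 (0.06 log units; within the scatter) and the step of a 1.2-fold lower number from compound 2 to compound 4 (0.09 log units; within the scatter) show that methoxy, para to a large group, cannot be told apart from ethyl or hydrogen, even though it brings a hydrogen-bond acceptor. Chloro alone stands apart, now against three groups, with an at least 5.7-fold lower number from compound 1 to compound 4 (0.76 log units; beyond the scatter) read as a bound from a limit: the limit of > 32000 nM in this assay, at which 1 of the 4 values shown sits.

Open, as far as these compounds go, is whether an amine, a carboxylic acid or a longer chain here would leave this level. Also open, from the compounds shown here alone, is whether fluoro or bromo would follow chloro.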